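Swapping a Fluorophenyl for a Hydroxyphenyl: Cytotoxicity Outlook

This account rests on a few compounds, and the source may have more. Where it says the series, first, only, none or still open, it means among the compounds named here.

Compound 3 `COc1ccccc1-c1nnc(-c2ccc(C(=O)N/N=C/c3ccccc3F)cc2)o1` gives 313000 nM in an ADME assay on THP-1 cells (Homo sapiens) for cytotoxicity (a lower number here means a stronger inhibitor, a higher number a weaker inhibitor), the highest of the three numbers measured, although its gap to compound 1 lies within the usual scatter. Compound 1 `COc1ccccc1-c1nnc(-c2ccc(C(=O)N/N=C/c3ccc([N+](=O)[O-])cc3)cc2)o1` gives 203000 nM in this assay, and compound 2 `COc1ccccc1-c1nnc(-c2ccc(C(=O)N/N=C/c3cccc([N+](=O)[O-])c3)cc2)o1` gives 119000 nM. The steps among these three are small: a 1.7-fold lower number from compound 1 to compound 2 (0.23 log units; within the scatter), a 1.5-fold higher number from compound 1 to compound 3 (0.19 log units; within the scatter), and a 2.6-fold higher number from compound 2 to compound 3 (0.42 log units; beyond the scatter). Compound 4 `COc1ccccc1-c1nnc(-c2ccc(C(=O)N/N=C/c3ccc(O)cc3)cc2)o1` has not been measured yet; it differs from compound 3 in one place: 4-hydroxyphenyl in place of 2-fluorophenyl on a carbon with a double bond to nitrogen. Among the compounds with values here, no measured step involves a 4-hydroxyphenyl, so the earlier steps bear on this change only by showing how little the number moved when the group on the carbon with a double bond to nitrogen was exchanged, as seen in a 1.5-fold higher number from compound 1 to compound 3 (0.19 log units; within the scatter) and a 2.6-fold higher number from compound 2 to compound 3 (0.42 log units; beyond the scatter). On that basis no step beyond the scatter is expected, and compound 4 is expected to show a 1.4-fold lower number from compound 3 to compound 4 (0.15 log units; within the scatter). Compound 4 is therefore estimated at 220000 nM in this assay, with a range from 90000 nM to 550000 nM.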

Compound 4, half-maximal inhibitory concentration: 261000 nM
For compound 4 the middle estimate is 1.2-fold (0.07 log units) below the measured one; the measured number falls inside the stated range.
By their numbers in this assay, from the lowest: compounds 2, 1, 4 and 3 (each within the scatter of the next, the first and the last beyond it).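

Within the data shown here, the 4-hydroxyphenyl brings a hydrogen-bond donor to the carbon with a double bond to nitrogen, a feature absent from the earlier compounds, yet this assay shows a 1.2-fold lower number from compound 3 to compound 4 (0.08 log units; within the scatter). Hydroxy in place of nitro on an aromatic carbon gives a similarly small change, with a 1.3-fold higher number from compound 1 to compound 4 (0.11 log units; within the scatter), whereas the change from 3-nitrophenyl gives a 2.2-fold higher number from compound 2 to compound 4 (0.34 log units; beyond the scatter), so compound 2 is the only compound whose step to compound 4 lies beyond the scatter. Nothing available explains why the numbers fall as they do.

These compounds leave open whether an amine or a carboxylic acid on the phenyl ring would shift the number further. They also leave open whether a longer chain in place of the phenyl ring would be tolerated as well.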